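Amide Aryl Swaps on a Shared Core

This account rests on a few compounds, and the source may have more. Where it says the series, first, only, none or still open, it means among the compounds named here.

Compound 1 `CCc1ccc(C(=O)Nc2ccc3nc(N4CCN(CC)CC4)cc(C)c3c2)cc1` gives 9850 nM in a functional assay on SK-BR-3 cells (Homo sapiens) for antiproliferative activity, read by MTT assay, with a stated time of 72 h; a lower number here means a stronger inhibitor, a higher number a weaker inhibitor.
Compound 2 `CCN1CCN(c2cc(C)c3cc(NC(=O)c4ccccc4OC)ccc3n2)CC1` gives 15700 nM in this assay.
Compound 3 `CCN1CCN(c2cc(C)c3cc(NC(=O)c4ccccc4Cl)ccc3n2)CC1` reaches only the assay limit, > 50000 nM, in this assay.

Among the two numbers shown, compound 1 holds the lowest, with compound 2 nearest to it; the gap a 1.6-fold higher number from compound 1 to compound 2 (0.20 log units; within the scatter) lies within the scatter. The two steps that move beyond the scatter both end at the limit of > 50000 nM in this assay, at which 1 of the 3 values shown sits: an at least 5.0-fold higher number from compound 1 to compound 3 (0.70 log units; beyond the scatter) and an at least 3.1-fold higher number from compound 2 to compound 3 (0.50 log units; beyond the scatter).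

Compound 4 `CCN1CCN(c2cc(C)c3cc(NC(=O)c4cc5ccccc5[nH]4)ccc3n2)CC1` differs from compound 1 by 1H-indol-2-yl in place of 4-ethylphenyl on a carbonyl carbon. Within the data shown here, every measured step at this same carbonyl carbon replaced one six-membered aromatic ring by another; none brings in a bicyclic group or a hydrogen-bond donor, so no step maps directly onto this change. What the steps do show is that changing the aryl group here either left the number unchanged within the scatter or raised it by an at least modest amount. Compound 4 is therefore expected to give a number no lower than compound 1, with a modest rise, a 2.0-fold higher number from compound 1 to compound 4 (0.31 log units; beyond the scatter), the most likely outcome. The estimate for compound 4 in this assay is 20000 nM, between 6000 nM and 50000 nM.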

Compound 4, half-maximal inhibitory concentration: 2550 nM
For compound 4 the middle estimate is 7.8-fold (0.89 log units) above the measured one; the whole stated range lies above it.
By their numbers in this assay, from the lowest: compound 4; then compounds 1 and 2 (each within the scatter of the next). At a limit, above all of these: compound 3.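

The earlier changes at this carbonyl carbon either stayed within the scatter or raised the number, so 1H-indol-2-yl is the first group shown here to lower it in this assay, with a 3.9-fold lower number from compound 1 to compound 4 (0.59 log units; beyond the scatter) and a 6.2-fold lower number from compound 2 to compound 4 (0.79 log units; beyond the scatter). The widest step is an at least 19-fold lower number from compound 3 to compound 4 (1.29 log units; beyond the scatter). That step gives only a bound, since compound 3 stands at a limit of the assay and not at a number: the limit of > 50000 nM in this assay, at which 1 of the 4 values shown sits.

The 1H-indol-2-yl group brings in a five-membered aromatic ring and a hydrogen-bond donor together, so the compounds shown cannot separate the contribution of one from the other. As far as these compounds go, whether a naphthyl group, which has two fused rings and no ring nitrogen, would lower the number in this assay as well remains open.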